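The compounds below may be only part of what the source reports. "The series", "measured", "known", "first", "only" and "open" are said of these compounds alone.

Compound 2 `COc1ccc(CN(C(=O)Nc2ccc(F)c(Cl)c2)n2cnnc2)cc1OC` stands at the weaker end of the numbers obtained in a functional assay on MDA-MB-231 cells (Homo sapiens) for cytotoxicity, read by MTT assay, with a stated time of 48 h; on this read-out higher numbers stand for weaker inhibition and lower numbers for stronger inhibition. In this assay compound 2 gives 27900 nM, the highest of the two numbers reported. Its nearest neighbour is compound 3 `N#Cc1ccc(CN(C(=O)Nc2cc(C(F)(F)F)cc(C(F)(F)F)c2)n2cnnc2)cc1`, which in this assay gives 9280 nM, a gap beyond the scatter. Compound 1 `COc1ccc(CN(C(=O)Nc2ccc(Cl)cc2)n2cnnc2)cc1OC` in this assay gives only the limit > 50000 nM. Among the compounds with values here, the single measured step that touches the aryl group on the amide-type nitrogen is an at least 1.7-fold lower number from compound 1 to compound 2 (0.25 log units; that floor lies within the scatter), and its floor lies within the scatter, so the direction is suggested rather than established. Compound 4 `COc1ccc(CN(C(=O)Nc2ccc(C)cc2)n2cnnc2)cc1OC` differs from compound 2 by 4-methylphenyl in place of 3-chloro-4-fluorophenyl on an amide-type nitrogen. Because compound 1 sits at the limit of > 50000 nM in this assay, at which 1 of the 3 values shown sits, compound 4 is expected to show a 1.8-fold higher number from compound 2 to compound 4 (0.25 log units; within the scatter) in this assay. The estimate for compound 4 in this assay is 50000 nM, with a range from 20000 nM to 120000 nM, and a limit instead of a number is considered a real possibility.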

Compound 4, half-maximal inhibitory concentration: > 50000 nM
Compound 4: no number, only a limit; the forecaster's own chance of this, stated with the estimate: 60%; the middle value sits exactly at the limit.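

In this assay, the change from 3-chloro-4-fluorophenyl to 4-methylphenyl on the amide-type nitrogen gives an at least 1.7-fold higher number from compound 2 to compound 4 (0.25 log units; that floor lies within the scatter), so this second change at the position again only suggests a direction. Within the data shown here, compound 4 gives only a limit, which leaves compound 2 as the one compound among compounds 1, 2 and 4 with a number: the limit of > 50000 nM in this assay, at which 2 of the 4 values shown sit. The step between compound 1 and compound 4, methyl in place of chloro on an aromatic carbon, cannot be read, as both values are limits.

From the compounds shown here alone, it remains open how an amine or a carboxylic acid on this phenyl ring would read in this assay. Also open, going by these compounds, is how 4-methylphenyl would read on the core of compound 3, which carries a nitrile.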